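Linker length at the sulfur of a nucleoside core

The compounds below may be only part of what the source reports. "The series", "measured", "known", "first", "only" and "open" are said of these compounds alone.

Three nucleoside analogues sharing one core have been tested in an assay on isolated protein for binding affinity to Equilibrative nucleoside transporter 1 (Homo sapiens); a higher number here means a weaker inhibitor, a lower number a stronger inhibitor. Compound 1 `CC(C)(Sc1ncnc2c1ncn2[C@@H]1O[C@H](CO)[C@@H](O)[C@H]1O)c1ccccc1` gives 21400 nM. Compound 2 `OC[C@H]1O[C@@H](n2cnc3c(SCCCc4ccccc4)ncnc32)[C@H](O)[C@@H]1O` gives 1350 nM. Compound 3 `OC[C@H]1O[C@@H](n2cnc3c(Sc4ccccc4)ncnc32)[C@H](O)[C@@H]1O` gives 91200 nM, the highest of the three numbers; it is weaker than compound 1 by a 4.3-fold higher number from compound 1 to compound 3 (0.63 log units; beyond the scatter) and weaker than compound 2 by a 68-fold higher number from compound 2 to compound 3 (1.83 log units; beyond the scatter). Both of these steps put the phenyl ring directly on the sulfur, and both raised the number, the more so the longer the chain removed.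

Compound 4 `OC[C@H]1O[C@@H](n2cnc3c(CSc4ccccc4Cl)ncnc32)[C@H](O)[C@@H]1O` is not yet measured. It differs from compound 3 by ((2-chlorophenyl)sulfanyl)methyl in place of phenylsulfanyl on an aromatic carbon: the phenyl ring is again carried away from the core, this time by one methylene, and it gains a chlorine. The step from compound 2 to compound 3 is the one that bears most on this, since it shows how strongly this assay responds to placing the ring at a distance from the core. Compound 4 is therefore expected to reach 10000 nM, within 2000 nM to 50000 nM, meaning an expected step of a 9.1-fold lower number from compound 3 to compound 4 (0.96 log units; beyond the scatter).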

Compound 4, half-maximal inhibitory concentration: 1780 nM
Estimate against measurement, compound 4: 5.6-fold (0.75 log units) above; measured number outside the range, below it.
By their numbers in this assay, from the lowest: compounds 2 and 4 (each within the scatter of the next); then compound 1; then compound 3.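

In this assay, replacing phenylsulfanyl with ((2-chlorophenyl)sulfanyl)methyl gives a 51-fold lower number from compound 3 to compound 4 (1.71 log units; beyond the scatter), so a low number at this position does not depend on the sulfur being attached directly to the core. Compounds 2 and 4 lie within the scatter of each other, which shows that a long chain such as 3-phenylpropyl on the sulfur is not the only route to this range: a methylene between the core and the sulfur, together with a chlorine on the phenyl ring, also reaches it. Nothing available here explains this gain.

This step adds the methylene and the chlorine together, so their separate contributions cannot be told apart. Going by these compounds, it remains open whether (phenylsulfanyl)methyl without the chlorine, or a variant with methoxy in its place, would give a similar number.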